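Benzyl in Place of Tolyl on the Sulfonyl Group

A few compounds are considered here, and "the series" means these few. Any claim that something is new, unique, unknown or untested is made for them only; others in the source may bear on it.

The compounds share one core. Compound 1 `COc1ccc(-c2cc(=O)c3c(OC)cc(OC)cc3n2S(=O)(=O)c2ccc(C#N)cc2)cc1` carries a cyano group on the aromatic ring of its sulfonyl substituent, while compound 2 `COc1ccc(-c2cc(=O)c3c(OC)cc(OC)cc3n2S(=O)(=O)c2ccc(C)cc2)cc1` carries a methyl group there. In a functional assay on SUP-B15 cells (Homo sapiens) for antiproliferative activity, with a stated time of 72 h (on this read-out lower numbers stand for an effect already at smaller amounts and higher numbers for an effect only at larger amounts of compound), compound 1 gives 7900 nM. For compound 2 the measurement reports only a limit, > 44800 nM, not a number. The step of an at least 5.6-fold higher number from compound 1 to compound 2 (0.75 log units; beyond the scatter) therefore points toward weaker activity, and compound 2 stands at the edge of what can be seen, namely (the limit of > 44800 nM in this assay, at which 1 of the 2 values shown sits).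

Compound 3 `COc1ccc(-c2cc(=O)c3c(OC)cc(OC)cc3n2S(=O)(=O)Cc2ccccc2)cc1` takes a further step: benzyl in place of 4-methylphenyl on a sulfonyl sulfur. Going by the values given here, no measured pair here alters the group on the sulfonyl sulfur; the only measured step, from compound 1 to compound 2, exchanges a substituent on that aromatic ring, so it gives no direct guide to this change. Because compound 2 sits at the limit of > 44800 nM in this assay, at which 1 of the 2 values shown sits, any real difference could stay hidden. The step of an at least 1.1-fold lower number from compound 2 to compound 3 (0.04 log units; that floor lies within the scatter) is expected to lie within the scatter. Compound 3 is accordingly estimated at 40000 nM in this assay, with a range from 10000 nM to 150000 nM.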

Compound 3, half-maximal effective concentration: > 34400 nM
Compound 3 ended at the assay's limit; the forecaster's own chance of this, stated with the estimate: 60%; the middle value does not contradict the limit.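

In this assay, benzyl in place of 4-cyanophenyl on the sulfonyl sulfur gives an at least 4.3-fold higher number from compound 1 to compound 3 (0.63 log units; beyond the scatter), so a second replacement of the 4-cyanophenyl group, after 4-methylphenyl, also moves toward weaker activity. Of the three groups shown on the sulfonyl sulfur, only 4-cyanophenyl gives a real number, with compound 1 at 7900 nM. For compound 3 the read-out is a limit of the assay and not a number: the limit of > 34400 nM in this assay, at which 1 of the 3 values shown sits.

The step from compound 2 to compound 3 cannot be read, so 4-methylphenyl and benzyl cannot be ranked against each other at this position. As far as these compounds go, it also stays open whether the nitrile alone or the ring attached directly to the sulfur goes with the measurable effect: a 4-cyanobenzyl group on the sulfonyl sulfur would combine the nitrile with the benzyl link, and a carboxylic acid or an amine in place of the nitrile on the phenyl ring would test other groups at that spot.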